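The source may hold more compounds than are shown below. What is called first, only, known or untested is meant among the compounds shown, and "the series" means these compounds.

In a functional assay on A549 cells (Homo sapiens) for antiproliferative activity, read by MTT assay, with a stated time of 24 h (a higher number here means a weaker inhibitor, a lower number a stronger inhibitor), compound 1 `C=CCc1cc(-c2cccc(C(F)(F)F)c2)ccc1O` gives 73000 nM. Compound 2 `C=CCc1cc(-c2cccc([N+](=O)[O-])c2)ccc1O` gives > 100000 nM, which is a limit of the assay and not a number. Compound 3 `C=CCc1cc(-c2ccccc2)ccc1O` gives > 100000 nM, which is also a limit. The position of compound 2 is therefore known only as a limit, and the main constraint on any expectation is the limit of > 100000 nM in this assay, at which 2 of the 3 values shown sit.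

Compound 4 `C=CC(C)(C)c1cc(-c2cccc([N+](=O)[O-])c2)ccc1O` keeps the nitro group of compound 2 and changes the group ortho to the hydroxy group: 1,1-dimethylprop-2-en-1-yl in place of allyl on an aromatic carbon. In words, 1,1-dimethylprop-2-en-1-yl replaces allyl on an aromatic carbon.

Three measured steps are available, and they bear on this change only loosely. Two have readable floors: an at least 1.3-fold higher number from compound 1 to compound 2 (0.13 log units; that floor lies within the scatter), and an at least 1.3-fold higher number from compound 1 to compound 3 (0.13 log units; that floor lies within the scatter). The third gives no size: a step that the two limits leave unreadable from compound 2 to compound 3. All three swap a different group and leave the allyl group untouched, so none of them shows what this replacement does.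

With no measured guide, no step beyond the scatter is expected in this assay, and no direction is favoured. The estimated step is a number no higher from compound 2 to compound 4 (the limit leaves the size open). Compound 4 may well be reported only as a limit again. As a number, compound 4 is expected near 100000 nM. The expected range for compound 4 runs from 45000 nM to 200000 nM.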

Compound 4, half-maximal inhibitory concentration: 64000 nM
For compound 4 the middle estimate is 1.6-fold (0.19 log units) above the measured one; low and high end bracket the measured number.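

In this assay, for the compounds shown here, the earlier steps changed only trifluoromethyl, nitro or hydrogen and left the allyl group untouched, so this result is the first reading of the place ortho to a hydroxy group. With the nitro group held fixed, 1,1-dimethylprop-2-en-1-yl in place of allyl, with 5 heavy atoms against 3, gives an at least 1.5-fold lower number from compound 2 to compound 4 (0.19 log units; that floor lies within the scatter). The more heavily branched chain therefore brings no visible loss of activity here, but no real gain can be claimed, because the comparison starts from a limit and its floor stays within the scatter: the limit of > 100000 nM in this assay, at which 2 of the 4 values shown sit.

On these data alone, what a saturated propyl chain, an amine or a carboxylic acid would do at this place remains open, as does whether the double bond of the chain matters at all. It is also open whether 1,1-dimethylprop-2-en-1-yl would act in the same way with trifluoromethyl or hydrogen in place of the nitro group, since the single step shown holds only for the pair with the nitro group.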